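Swapping phenyl for thiophen-3-yl in compound 4

The compounds below may be only part of what the source reports. "The series", "measured", "known", "first", "only" and "open" are said of these compounds alone.

Measured in a functional assay on CCRF-CEM cells (Homo sapiens) for cytotoxicity, read by XTT assay, with a stated time of 3 days; on this read-out lower numbers stand for stronger inhibition and higher numbers for weaker inhibition:
- compound 1 `OC[C@H]1O[C@@H](n2cc(F)c3c(-c4ccccc4)ncnc32)[C@H](O)[C@@H]1O`: 3100 nM
- compound 2 `OC[C@H]1O[C@@H](n2cc(F)c3c(-c4ccc[nH]4)ncnc32)[C@H](O)[C@@H]1O`: 410 nM
- compound 3 `OC[C@H]1O[C@@H](n2cc(Cl)c3c(-c4ccccc4)ncnc32)[C@H](O)[C@@H]1O`: 910 nM

Among these three numbers, compound 3 sits in the middle at 910 nM. Compound 2 has a lower number and compound 1 a higher one. Compound 4 `OC[C@H]1O[C@@H](n2cc(Cl)c3c(-c4ccsc4)ncnc32)[C@H](O)[C@@H]1O` differs from compound 3 in one place, with thiophen-3-yl in place of phenyl on an aromatic carbon.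

The closest guide is a 7.6-fold lower number from compound 1 to compound 2 (0.88 log units; beyond the scatter), where 1H-pyrrol-2-yl replaced phenyl. That modest step goes beyond the usual scatter, but it is the only phenyl replacement measured so far. It also involves a different ring and a fluoro compound rather than a chloro one, so it transfers only loosely. The other step, a 3.4-fold lower number from compound 1 to compound 3 (0.53 log units; beyond the scatter), is also modest, but it swaps fluoro for chloro. Compound 3 and compound 4 both carry chloro, so that change plays no part here.

A modest move to a lower number in this assay is therefore expected, though with wide uncertainty. For compound 4 the estimated value is 150 nM. For compound 4 the estimated range runs from 35 nM to 700 nM. The expected change is a 6.1-fold lower number from compound 3 to compound 4 (0.78 log units; beyond the scatter).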

Compound 4, half-maximal inhibitory concentration: 1000 nM
The estimate for compound 4 lay 6.7-fold (0.82 log units) below the measured number; the measured number lies above the stated range.
By their numbers in this assay, from the lowest: compound 2; then compounds 3 and 4 (each within the scatter of the next); then compound 1.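

In this assay, thiophen-3-yl in place of phenyl gives a 1.1-fold higher number from compound 3 to compound 4 (0.04 log units; within the scatter), so on the chloro compounds the two rings cannot be told apart at this position, even though the entering ring is five-membered, holds a sulfur atom and counts one hydrogen-bond acceptor where phenyl counts none. Swapping phenyl for a five-membered aromatic ring therefore does not by itself guarantee a lower number here, and the earlier step to 1H-pyrrol-2-yl, a 7.6-fold lower number from compound 1 to compound 2 (0.88 log units; beyond the scatter), which was seen on a fluoro compound, cannot be read as a general rule for such rings. Nothing available explains why the two ring swaps behave differently.

From the compounds shown here alone, it remains open whether 1H-pyrrol-2-yl would give a step of similar size on the chloro compound, and whether thiophen-3-yl would behave on the fluoro compound as it does on the chloro one, since only those pairings could separate the effect of the ring from that of the halogen. The compounds shown also leave open what an amine or a carboxylic acid would do at this position in place of an aromatic ring.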